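Bromo in place of methoxy: a small expected step

The source may hold more compounds than are shown below. What is called first, only, known or untested is meant among the compounds shown, and "the series" means these compounds.

Three related compounds have been measured in a functional assay on A549 cells (Homo sapiens) for antiproliferative activity, read by MTT assay, with a stated time of 48 h; on this read-out lower numbers stand for stronger inhibition and higher numbers for weaker inhibition. Compound 1 `Cc1ccc(-c2cc(NC(=O)/C=C/c3ccc(C(F)(F)F)cc3)n[nH]2)cc1` gives 1020 nM, compound 2 `O=C(/C=C/c1ccc(Br)cc1)Nc1cc(-c2ccccc2)[nH]n1` gives 1460 nM, and compound 3 `COc1ccc(/C=C/C(=O)Nc2cc(-c3ccc(C)cc3)[nH]n2)cc1` gives 1190 nM. Compound 3 lies within the usual scatter of both others, so these three numbers cannot be put in a real order.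

The next compound, compound 4 `Cc1ccc(-c2cc(NC(=O)/C=C/c3ccc(Br)cc3)n[nH]2)cc1`, matches compound 3 except for one group. It has bromo in place of methoxy on an aromatic carbon, para to a large group (bromo in place of methoxy on an aromatic carbon). The same difference can be read as 4-methoxyphenyl to 4-bromophenyl.

Within the data shown here, one measured step touches this same place. Methoxy in place of trifluoromethyl gave a 1.2-fold higher number from compound 1 to compound 3 (0.07 log units; within the scatter), so a change of group here has so far left the number within the scatter. Compound 2 already carries the 4-bromophenyl group, though it differs elsewhere in its structure, and compound 2 gives 1460 nM, which is within the scatter of the value for compound 3.

No step beyond the scatter is therefore expected in this assay. The estimated step is a 1.1-fold higher number from compound 3 to compound 4 (0.02 log units; within the scatter). For compound 4 the expected value is 1250 nM, with an estimated range of 750 nM to 2100 nM.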

Compound 4, half-maximal inhibitory concentration: 1590 nM
Beside the measured number, compound 4's estimate is 1.3-fold (0.10 log units) below it; measured number inside the range.
By their numbers in this assay, from the lowest: compounds 1, 3, 2 and 4 (each within the scatter of the next).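

In this assay, the change from 4-methoxyphenyl to 4-bromophenyl gives only a small step (a 1.3-fold higher number from compound 3 to compound 4 (0.13 log units; within the scatter)), and bromo in place of trifluoromethyl at the same place also stays small (a 1.6-fold higher number from compound 1 to compound 4 (0.19 log units; within the scatter)). Together with the earlier step between methoxy and trifluoromethyl, this means that all three groups at this place have now been compared directly, and no pair separates beyond the usual scatter. Compound 4 also opens a second comparison elsewhere in the structure, where methyl in place of hydrogen on an aromatic carbon leaves the number just as unmoved (a 1.1-fold higher number from compound 2 to compound 4 (0.04 log units; within the scatter)), so neither place has yet produced a step large enough to rank its groups.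

As far as these compounds go, whether a very different group at this place, such as an amine or a carboxylic acid, would move the number beyond the scatter remains open. No measurement is available that could explain why these changes leave the number so little altered.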